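Extending the Chain in a Series Showing No Effect

The source may hold more compounds than are shown below. What is called first, only, known or untested is meant among the compounds shown, and "the series" means these compounds.

Measured so far:
compound 1, `COc1cccc(N2CCN(C(=O)C(C)N3C(=O)CCC3=O)CC2)c1`: 0%
compound 2, `CCC(C(=O)N1CCN(c2cccc(F)c2)CC1)N1C(=O)CCC1=O`: 0%
compound 3, `CC(C(=O)N1CCN(c2ccccc2F)CC1)N1C(=O)CCC1=O`: 0%

Of the compounds shown here, three have been tested in a functional assay on the whole organism (strain Swiss) with Mus musculus as the target, in the maximal electroshock model, with a stated time of 2 h, at a dose of 100 mg/kg by the intraperitoneal route (on this read-out higher numbers stand for a stronger effect at the one dose given and lower numbers for a weaker effect), and none of them produced a measurable effect. Compound 3 stands level with compound 1 and compound 2 at the digits shown. Going by the values given here, the only single-point step among them, no change at the digits printed from compound 1 to compound 3 (within the scatter), is within the scatter, so exchanging the aryl group on the ring amine nitrogen made no visible difference here. Compound 1 and compound 2 differ in more than one place, and their two values are both at the floor of the read-out.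

The next compound, compound 4 `CCC(C(=O)N1CCN(c2ccccc2F)CC1)N1C(=O)CCC1=O`, differs from compound 3 by methyl in place of hydrogen on a saturated chain carbon, two bonds along the chain from an amide-type nitrogen in a ring and a carbonyl carbon. Among the compounds with values here, no measured step covers exactly this change. What can be said is that compound 2, which already carries the longer chain, gives 0% in this assay, and that compound 3 gives 0%; the two are the same. Within the data shown here, with every measured compound at the floor and the one measured step within the scatter, the step of no change at the digits printed from compound 3 to compound 4 (within the scatter) is expected to show no change beyond the scatter. Compound 4 is therefore estimated at 0% in this assay, with a range of 0% to 10%.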

Compound 4, a percentage reported as activity, at one dose (the size of the read-out at that dose, not a potency): 0%
Estimate against measurement, compound 4: no gap at the digits printed; the range from low to high includes it.
By their numbers in this assay, from the lowest: compounds 1, 2, 3 and 4 (each within the scatter of the next).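

In this assay, the change of hydrogen to methyl on a saturated chain carbon, two bonds along the chain from an amide-type nitrogen in a ring and a carbonyl carbon, now has a direct reading, and it gives no change at the digits printed from compound 3 to compound 4 (within the scatter) in a pair with 2-fluorophenyl on the amine nitrogen. With the ethyl-bearing chain held the same, the exchange of 3-fluorophenyl for 2-fluorophenyl on an amine nitrogen in a ring gives no change at the digits printed from compound 2 to compound 4 (within the scatter) as well, so this aryl change joins the chain change in leaving the read-out at its floor. Nothing available bears on why these compounds stay at that level.

With all four compounds at the floor, neither step can show whether the added methyl would matter in a compound that has a measurable effect, since a read-out at its floor cannot register a further loss. Also open, on these data alone, is whether a longer chain such as propyl at this carbon, or a hydroxyl or an amine placed on that chain, would lift the series off the floor in this assay at all.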